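The source may report more compounds than this note shows. Statements on the series, on what has been measured and on what is new or still open speak of the compounds shown alone.

Measured compounds:
- Compound 1 `CCOC(=O)C1CCN(C(=O)CN2CN(c3ccccc3)C3(CCN(C(=O)c4ccc(C5CCCCC5)cc4)CC3)C2=O)CC1`: in an assay on HEK293 cells for displacement of a labelled ligand from NPC1-like intracellular cholesterol transporter 1 (Homo sapiens) (a lower number here means a stronger inhibitor, a higher number a weaker inhibitor), compound 1 gives 900 nM
- Compound 2 `CC(C)(C)OC(=O)NCCCCCNC(=O)CN1CN(c2ccccc2)C2(CCN(C(=O)c3ccc(C(C)(C)C)cc3)CC2)C1=O`: compound 2 gives 13700 nM
- Compound 3 `CC(C)(C)c1ccc(C(=O)N2CCC3(CC2)C(=O)N(CC(=O)NCCN)CN3c2ccccc2)cc1`: compound 3 gives 7000 nM

Compound 3 stands second highest of the three numbers. Going by the values given here, its nearest neighbour is compound 2, and the only step between compounds that differ in one place, a 2.0-fold lower number from compound 2 to compound 3 (0.29 log units; within the scatter), lies within the scatter. The gap from compound 3 to compound 1 is beyond the scatter, but these two differ in more than one place, so their values can only be compared, not read as a single step.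

Compound 4 `CCOC(=O)C1CCN(C(=O)CN2CN(c3ccccc3)C3(CCN(C(=O)c4ccc(C(C)(C)C)cc4)CC3)C2=O)CC1` carries the change (4-(ethoxycarbonyl)piperidin-1-yl in place of (2-aminoethyl)amino on a carbonyl carbon). Among the compounds with values here, no measured step covers this exchange of the amide substituent. Within the data shown here, the one step available, from compound 2 to compound 3, altered the same amide substituent and produced no movement beyond the scatter. Among the measured compounds shown here, compound 1, the only measured compound bearing the 4-(ethoxycarbonyl)piperidin-1-yl group, shows the lowest number of the three, though it also differs from compound 4 in the aroyl substituent. On that basis the expected step of a 3.9-fold lower number from compound 3 to compound 4 (0.59 log units; beyond the scatter) in this assay is toward a lower number, of moderate size and uncertain. Compound 4 is estimated at 1800 nM, with a range from 500 nM to 7000 nM.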

Compound 4, half-maximal inhibitory concentration: 3100 nM
For compound 4 the middle estimate is 1.7-fold (0.24 log units) below the measured one; measured number inside the range.
By their numbers in this assay, from the lowest: compound 1; then compound 4; then compounds 3 and 2 (each within the scatter of the next).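

Working notes: in this assay the amide substituent now gives a readable change, with 4-(ethoxycarbonyl)piperidin-1-yl in place of (2-aminoethyl)amino on a carbonyl carbon giving a 2.3-fold lower number from compound 3 to compound 4 (0.35 log units; beyond the scatter) where the earlier change at this position, a 2.0-fold lower number from compound 2 to compound 3 (0.29 log units; within the scatter), gave no movement beyond the scatter. Going by these compounds alone, the second step reads a different position for the first time, with tert-butyl in place of cyclohexyl on an aromatic carbon giving a 3.4-fold higher number from compound 1 to compound 4 (0.54 log units; beyond the scatter), so compound 4 links compound 1 and compound 3 through two single-place changes, both modest. No supporting data bear on either step.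

Open, as far as these compounds go, is whether the step at the carbonyl carbon follows the piperidine ring or the ethyl ester, which a plain piperidine or a piperidine carrying a free carboxylic acid would help to separate. Also open, from the compounds shown here alone, is whether the exchange of tert-butyl and cyclohexyl reads the same with a different amide substituent, such as (2-aminoethyl)amino, or with a longer amine chain.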